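The source may report more compounds than this note shows. Statements on the series, on what has been measured and on what is new or still open speak of the compounds shown alone.

Compound 1, `COCc1nc(C)c2c(C)nnc(O)n12`: in a functional assay for inhibition, with Homo sapiens as the target (on this read-out higher numbers stand for weaker inhibition and lower numbers for stronger inhibition), compound 1 gives > 48000 nM, which is a limit of the assay.
Compound 2, `CCCc1nc(C)c2c(C(C)C)nnc(O)n12`: in this assay compound 2 gives > 48000 nM, again a limit of the assay.
Compound 3, `C=CCn1nc(CCC)c2c(C)nc(CCC)n2c1=O`: in this assay compound 3 gives 29000 nM.

Compound 2 therefore stands at the limit rather than at a number, and it shares that position with compound 1, as the limit of > 48000 nM in this assay, at which 2 of the 3 values shown sit, shows; only compound 3 gives a number at all, and that number is close to the same limit. Among the compounds with values here, no step between any two measured compounds differs in one place, so no measured step is available to guide the change that leads to compound 4, `CCCc1nc(C)c2c(C(C)C)nnc(S)n12`. Compound 4 differs from compound 2 by sulfanyl in place of hydroxy on an aromatic carbon. With both neighbours of the change at or near the limit, the account gives no basis for expecting a shift beyond the scatter in either direction in this assay, and the most likely outcome is that compound 4 is again reported only as a limit. Compound 4 is therefore expected to give about 48000 nM, in a range from 20000 nM to 120000 nM. The estimated step of a number no higher from compound 2 to compound 4 (the limit leaves the size open) is expected to be none beyond the scatter.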

Compound 4, half-maximal inhibitory concentration: > 48000 nM
Compound 4: only a limit was reported (the forecaster's own chance of this, stated with the estimate: 70%); the middle value sits exactly at the limit.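

In this assay compound 4 gives > 48000 nM, which is a limit of the assay. Compound 2 also stands at a limit, so no step can be read between compound 2 and compound 4. The compounds shown leave open whether sulfanyl in place of hydroxy on an aromatic carbon changes inhibition at all, and in which direction.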